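The compounds below may be only part of what the source reports. "The series", "measured", "known", "first", "only" and "open" are said of these compounds alone.

Measured compounds:
Compound 1, `CC[C@H]1CN(c2nc(N)c(C(N)=O)nc2Cl)CCN1C1CCN(Cc2ccc(C#N)cc2)CC1`: 8.5 nM
Compound 2, `CC[C@H]1CN(c2nc(N)c(C(N)=O)nc2Cl)CCN1C1CCN(C(=O)c2ccc(Cl)cc2)CC1`: 76 nM
Compound 3, `CC[C@H]1CN(c2nc(N)c(C(=O)NC)nc2Cl)CCN1C1CCN(Cc2ccc(Cl)cc2)CC1`: 0.3 nM

All three were tested in an in vitro assay on BaF3 cells for displacement of a labelled ligand from C-X-C chemokine receptor type 3 (Homo sapiens); on this read-out lower numbers stand for stronger inhibition and higher numbers for weaker inhibition. Compound 3 gives the lowest number of the three; compound 1 is nearest to it, and compound 2 stands furthest away. Within the data shown here, the only step measured between two compounds that differ in one place is an 8.9-fold higher number from compound 1 to compound 2 (0.95 log units; beyond the scatter), which concerns the group on the amine nitrogen of the piperidine ring, not the amide.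

Compound 4, `CC[C@H]1CN(c2nc(N)c(C(=O)NCCNS(N)(=O)=O)nc2Cl)CCN1C1CCN(Cc2ccc(Cl)cc2)CC1`, is made from compound 3 by the change ((sulfamoylamino)methyl in place of hydrogen on a saturated chain carbon bound to an amide-type nitrogen). No measured step touches this part of the shared core, so the size and direction of the step cannot be read from the data shown; the change is expected to leave the number near that of compound 3, with a loss of potency at least as likely as a gain. The expected step is a 3.3-fold higher number from compound 3 to compound 4 (0.52 log units; beyond the scatter), giving an estimate for compound 4 of 1 nM, between 0.2 nM and 6 nM.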

Compound 4, half-maximal inhibitory concentration: 1.9 nM
Beside the measured number, compound 4's estimate is 1.9-fold (0.28 log units) below it; measured number inside the range.
By their numbers in this assay, from the lowest: compound 3; then compound 4; then compound 1; then compound 2.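

Placing (sulfamoylamino)methyl on the saturated chain carbon bound to the amide-type nitrogen gives a 6.3-fold higher number from compound 3 to compound 4 (0.80 log units; beyond the scatter) and so costs some potency. Even so, compound 4 keeps a low number at 1.9 nM, which shows that this position accepts a much larger group with no net charge. Nothing available explains the size of this step. From the compounds shown here alone, it remains open whether the sulfamoylamino end or the longer chain alone accounts for the loss. A plain propyl chain, or a chain ending in an amine or a carboxylic acid, would help separate the two.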